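From compound 1 to compound 3: a changed ring group

This account rests on a few compounds, and the source may have more. Where it says the series, first, only, none or still open, it means among the compounds named here.

Measured in an ADME assay on KB cells (Homo sapiens) for cytotoxicity, with a stated time of 48 h; a higher number here means a weaker inhibitor, a lower number a stronger inhibitor:
- compound 1 `C=C1[C@H](C)CCC[C@]1(C)CC/C(C)=C/CC1=C(O)C(=O)C=C(N[C@@H](C(=O)O)C(C)C)C1=O`: 6.2 ug/mL
- compound 2 `C=C1[C@H](C)CCC[C@]1(C)CC/C(C)=C/CC1=C(O)C(=O)C=C(N[C@@H](C(=O)O)[C@H](C)O)C1=O`: > 10 ug/mL (a limit of the assay)

Within the data shown here, compound 1, at 6.2 ug/mL, is the only compound here with an actual number. Compound 2 gives only a limit, > 10 ug/mL.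

Compound 3 `CC1=CCC[C@](C)(CC/C(C)=C/CC2=C(O)C(=O)C=C(N[C@@H](C(=O)O)C(C)C)C2=O)[C@@H]1C` has not yet been measured in this assay. It has the same atoms as compound 1, joined differently: a group of 9 heavy atoms (9 carbon; one six-membered non-aromatic ring of carbon only) in place of a group of 9 heavy atoms (9 carbon; one six-membered non-aromatic ring of carbon only), on a saturated chain carbon, two bonds along the chain from a double-bonded chain carbon. The incoming group is 1,2,3-trimethylcyclohex-3-en-1-yl. Among the measured compounds shown here, the only measured step, an at least 1.6-fold higher number from compound 1 to compound 2 (0.20 log units; that floor lies within the scatter), lies elsewhere in the molecule, so it does not bear directly on this exchange. No step beyond the scatter is therefore expected. The expected step is a 1.0-fold lower number from compound 1 to compound 3 (0.01 log units; within the scatter). Compound 3 is expected at 6 ug/mL. The estimated range for compound 3 runs from 3 ug/mL to 10.5 ug/mL.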

Compound 3, half-maximal inhibitory concentration: > 10 ug/mL
Compound 3 ended at the assay's limit; the forecaster's own chance of this, stated with the estimate: 15%; middle value at least 1.6-fold (0.22 log units) from the limit.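

The result shows that the ring end of the molecule, and not only the amino acid side chain, can carry a change after which this assay gives no number: with 1,2,3-trimethylcyclohex-3-en-1-yl in place, compound 3 sits at a limit of the assay, > 10 ug/mL. The change adds no atoms, yet the step reads only as an at least 1.6-fold higher number from compound 1 to compound 3 (0.20 log units; that floor lies within the scatter), so this floor does not set the two compounds apart beyond the scatter. How far the exchange truly moves the value cannot be told, because the reading stops at a limit: the limit of > 10 ug/mL in this assay, at which 2 of the 3 values shown sit.

The compounds shown leave open whether a saturated cyclohexyl ring or a phenyl ring at this place would give a number in this assay. They also leave open how a methyl ester in place of the carboxylic acid would read with either ring group.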